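A few compounds are considered here, and "the series" means these few. Any claim that something is new, unique, unknown or untested is made for them only; others in the source may bear on it.

Working notes on the cytotoxicity side of the series. Of the compounds shown here, two have been measured in an ADME assay on MT4 cells (Homo sapiens) for cytotoxicity, read by MTT assay; on this read-out higher numbers stand for lower toxicity in this test and lower numbers for higher toxicity in this test. Compound 1 `Cc1cnc(Nc2ccc(C#N)cc2)nc1NC1CC1` gives 360 nM in this assay. Compound 2 `N#Cc1ccc(Nc2nccc(SC3CCCCC3)n2)cc1` gives > 402000 nM in this assay, and this value is a limit of the assay, not a number. Among the compounds with values here, compound 2 thus stands at the untoxic end of what has been measured, at the limit of > 402000 nM in this assay, at which 1 of the 2 values shown sits, while compound 1 sits well inside the measurable range; no single-point step between compound 1 and compound 2 is on record, so only their two values are compared here.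

Compound 3 `Cc1cnc(Nc2ccc(C#N)cc2)nc1SC1CCCCC1` has not yet been measured in this assay. It differs from compound 2 by methyl in place of hydrogen on an aromatic carbon. Given the small size of this change, a step beyond the scatter is not expected, and the step from compound 2 to compound 3 is expected to be an at least 1.3-fold lower number from compound 2 to compound 3 (0.12 log units; that floor lies within the scatter). Compound 3 is therefore estimated to give 300000 nM in this assay, within a range of 80000 nM to 402000 nM, with a fair chance that only a limit is reported again.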

Compound 3, half-maximal cytotoxic concentration: 33400 nM
Beside the measured number, compound 3's estimate is 9.0-fold (0.95 log units) above it; measured number below the stated range.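

In this assay, the aromatic carbon ortho to the cyclohexylsulfanyl group proves sensitive: methyl in place of hydrogen there gives an at least 12-fold lower number from compound 2 to compound 3 (1.08 log units; beyond the scatter), a large change towards higher toxicity in this test from a single added carbon. Compound 2 stands at a limit of the assay and not at a number, so this step gives only a floor for the true size of the change: the limit of > 402000 nM in this assay, at which 1 of the 3 values shown sits. With the methyl kept, cyclohexylsulfanyl in place of cyclopropylamino gives a 93-fold higher number from compound 1 to compound 3 (1.97 log units; beyond the scatter), so the group at the neighbouring substituent site also moves the number well beyond the scatter.

On these data alone, whether an ethyl group or a chlorine on the same carbon would act as the methyl does remains open. Also open, as far as these compounds go, is whether the sulfur or the ring size carries the second step, which a cyclohexylamino or cyclopropylsulfanyl group would separate.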